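Dimethoxy for chloromethoxy on a thiourea-linked pyrimidine

This account rests on a few compounds, and the source may have more. Where it says the series, first, only, none or still open, it means among the compounds named here.

Three compounds sharing the dichlorophenyl-isoxazole carboxamide core were tested in a functional assay on the whole organism for inhibition, with Chenopodium ficifolium as the target, with a stated time of 72 h, tested at 10 mg/L; on this read-out lower numbers stand for less inhibition of growth and higher numbers for more inhibition of growth at the one concentration tested. Compound 1 `COc1cc(Cl)nc(NC(=S)NC(=O)c2c(-c3ccc(Cl)cc3Cl)noc2C)n1` gives 21.9%. Compound 2 `Cc1onc(-c2ccc(Cl)cc2Cl)c1C(=O)/N=c1/nc2nc(Cl)cc(C)n2s1`, with a fused ring system in place of the thiourea linker, gives 18.6%. Compound 3 `COc1cc(OC)n2s/c(=N\C(=O)c3c(-c4ccc(Cl)cc4Cl)noc3C)nc2n1`, another fused variant carrying two methoxy groups, gives 28.9%. All three numbers lie within the usual scatter of one another, so no ranking among them can be read from these data.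

Compound 4 `COc1cc(OC)nc(NC(=S)NC(=O)c2c(-c3ccc(Cl)cc3Cl)noc2C)n1` has not yet been measured. It differs from compound 1 only in one place: methoxy in place of chloro on an aromatic carbon. Within the data shown here, no step between two measured compounds isolates this change, so the size of its effect in this assay is unknown.

Compound 4 is expected to give 24%, with a range from 10% to 40%. This estimate corresponds to a step of a number 2.1 percentage points higher from compound 1 to compound 4 (within the scatter), which is expected to stay within the scatter rather than mark a real change in either direction.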

Compound 4, percent growth inhibition at one concentration: 30.7%
Beside the measured number, compound 4's estimate is 6.7 percentage points below it; measured number inside the range.
By their numbers in this assay, from the lowest: compounds 2, 1, 3 and 4 (each within the scatter of the next, the first and the last beyond it).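

In this assay, among these compounds, going from 4-chloro-6-methoxypyrimidin-2-yl to 4,6-dimethoxypyrimidin-2-yl gives a number 8.8 percentage points higher from compound 1 to compound 4 (within the scatter), the first step that isolates a single change. Methoxy in place of chloro on this aromatic carbon therefore shows no real effect on growth inhibition at the one concentration tested, and neither group can be ranked above the other here. Nothing shown gives a measured property that bears on this result.

Going by these compounds, whether an amine or a longer chain such as butoxy on the same carbon would move the read-out beyond the scatter stays open. Also open, on these data alone, is whether the same exchange would read alike on the fused compounds, as compound 2 and compound 3 differ in more than one place.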